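A Larger Ring Replaces a Methyl on the Side Chain

A few compounds are considered here, and "the series" means these few. Any claim that something is new, unique, unknown or untested is made for them only; others in the source may bear on it.

Of the compounds shown here, two built on a shared core have so far been tested in an assay for inhibition of histone-lysine N-methyltransferase EZH2 variant Y641N (Homo sapiens), read by scintillation counting, with a stated time of 60 min, in the presence of a further agent that is not named here; a lower number here means a stronger inhibitor, a higher number a weaker inhibitor. Compound 1, `Cc1cc(C)c(CN2CCc3c(Cl)cc([C@@H](C)CO)c(Cl)c3C2=O)c(=O)[nH]1`, gives 260 nM in this assay, the lower of the two numbers recorded. Compound 2, `COc1cc(C)[nH]c(=O)c1CN1CCc2c(Cl)cc([C@@H](O)C3COC3)c(Cl)c2C1=O`, gives 1500 nM in this assay, a higher number whose gap from compound 1 lies beyond the usual scatter, so compound 1 is the stronger inhibitor of the two measured. Compound 3, `Cc1cc(C)c(CN2CCc3c(Cl)cc([C@H](CO)[C@@H]4CCCO4)c(Cl)c3C2=O)c(=O)[nH]1`, has not yet been measured. It differs from compound 1 in a single place: oxolan-2-yl in place of methyl on a saturated chain carbon bound to an aromatic carbon and a saturated chain carbon. Among the compounds with values here, no pair of measured compounds that differ in only one place is available, so nothing measured shows directly how this change behaves. Compound 2 carries a different side chain on the same kind of carbon, but it also differs elsewhere and gives no clean guide. Compound 3 is therefore expected to give about 400 nM in this assay, estimated to fall between 130 nM and 1200 nM. This estimate implies an expected step of a 1.5-fold higher number from compound 1 to compound 3 (0.19 log units; within the scatter), a small move toward a weaker number, close to the scatter.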

Compound 3, inhibition constant: 10 nM
The estimate for compound 3 lay 40-fold (1.60 log units) above the measured number; the whole stated range lies above it.
By their numbers in this assay, from the lowest: compound 3; then compound 1; then compound 2.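

Oxolan-2-yl in place of methyl on a saturated chain carbon bound to an aromatic carbon and a saturated chain carbon gives, in this assay, a 26-fold lower number from compound 1 to compound 3 (1.41 log units; beyond the scatter), a large step and the first direct reading of any change at this position. It shows that this carbon can carry much more than methyl: a group of 1 heavy atom gives way to one of 5 heavy atoms, and compound 3 is a stronger inhibitor than compound 1, not a weaker one. No measurement at hand bears on the reason for this step.

The change brings in several things at once, namely a five-membered non-aromatic ring, a ring oxygen that counts as a hydrogen-bond acceptor and a new defined stereocentre, and this single pair cannot separate their shares in the step. As far as these compounds go, a cyclopentyl ring would test the ring without its oxygen, a methoxyethyl chain would test the oxygen without the ring, and the oxolan-2-yl group with its stereocentre inverted would test the spatial arrangement, so all three questions remain open here.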